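Chloro for fluoro on the aniline of compound 1

The source may hold more compounds than are shown below. What is called first, only, known or untested is meant among the compounds shown, and "the series" means these compounds.

Measured in an ADME assay on RAW264.7 cells (Mus musculus) for cytotoxicity, read by MTT assay, with a stated time of 24 h; a higher number here means that more compound is tolerated, a lower number that less compound is tolerated:
compound 1 `O=C(Nc1ccc(F)cc1F)c1cc(Br)ccc1O`: 13800 nM
compound 2 `O=c1oc2ccc(Cl)cc2c(=O)n1-c1ccc(Br)cc1F`: 8100 nM
compound 3 `O=C(Nc1ccc(Br)cc1F)c1cc(I)ccc1O`: 8400 nM

Compound 1 gives the highest of the three numbers, yet its gap to compound 3 and its gap to compound 2 both fall within the usual scatter, so the three compounds cannot be placed in any order on these values. No two of the measured compounds differ in a single place, so no step size is available from the series itself; the size of the change below has to be judged without a measured precedent.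

Compound 4 `O=C(Nc1ccc(Cl)cc1F)c1cc(Br)ccc1O` differs from compound 1 in one place: chloro in place of fluoro on an aromatic carbon. The change keeps the same amide and phenol core and exchanges one halogen for another on the aniline ring. Among the compounds with values here, because compound 1 stands at 13800 nM and the series offers no step for comparison, the step of a 1.2-fold lower number from compound 1 to compound 4 (0.06 log units; within the scatter) is expected to lie within the scatter, with no set direction. Compound 4 is therefore estimated at 12000 nM, in a range from 5000 nM to 30000 nM.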

Compound 4, half-maximal cytotoxic concentration: 9200 nM
The estimate for compound 4 lay 1.3-fold (0.12 log units) above the measured number; the range from low to high includes it.
By their numbers in this assay, from the lowest: compounds 2, 3, 4 and 1 (each within the scatter of the next).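

In this assay, within the data shown here, the step of a 1.5-fold lower number from compound 1 to compound 4 (0.18 log units; within the scatter) is the first single-place step available, and it stays within the scatter. Chloro in place of fluoro on this aromatic carbon, meta to a fluoro group and para to a large group, therefore gives no readable difference, something the earlier compounds, none differing from another in one place, could not show. Nothing on hand offers an explanation for this step.

Open, on these data alone, is whether a group other than a halogen at this position, such as a methoxy, an amine or a carboxylic acid, would give a step beyond the scatter. Also open, as far as these compounds go, is whether the same exchange of fluoro for chloro at the other fluoro group would stay within the scatter.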